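Swapping the nitrophenyl of compound 2 for an indazolyl

The source may hold more compounds than are shown below. What is called first, only, known or untested is meant among the compounds shown, and "the series" means these compounds.

The series shares a core in which an aryl group sits on a nitrogen on an aromatic ring. Compound 1 `CCOc1ccc(Cl)cc1-c1cc(Nc2ccc([N+](=O)[O-])cc2)nc(N)n1` carries a 4-nitrophenyl there and in an assay on Sf9 cells for inhibition of 1-acyl-sn-glycerol-3-phosphate acyltransferase beta (Homo sapiens) (on this read-out higher numbers stand for weaker inhibition and lower numbers for stronger inhibition), compound 1 gives 10 nM. For the measured compounds named here, compound 2 `CCOc1ccc(Cl)cc1-c1cc(Nc2cccc([N+](=O)[O-])c2)nc(N)n1` carries a 3-nitrophenyl instead, and in this assay compound 2 gives 640 nM, the highest of the two numbers measured so far; the only step measured, a 64-fold higher number from compound 1 to compound 2 (1.81 log units; beyond the scatter), shows that the pattern of the aryl group at this position can move the read-out a great deal.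

Compound 3 `CCOc1ccc(Cl)cc1-c1cc(Nc2ccc3c[nH]nc3c2)nc(N)n1` is not yet measured. It differs from compound 2 in one place: 2H-indazol-6-yl in place of 3-nitrophenyl on a nitrogen on an aromatic ring. Going by the values given here, no measured step covers an indazolyl at this position, so the one step measured bears on it only by showing how sensitive the read-out is to this group. Given that compound 2 stands at the high end, compound 3 is expected to return a lower number, with wide uncertainty, by an estimated 6.4-fold lower number from compound 2 to compound 3 (0.81 log units; beyond the scatter). The estimate for compound 3 is 100 nM, within a range from 15 nM to 1500 nM.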

Compound 3, half-maximal inhibitory concentration: 24 nM
Compound 3: middle estimate off by 4.2-fold (0.62 log units), on the high side; the measured number falls inside the stated range.
By their numbers in this assay, from the lowest: compound 1; then compound 3; then compound 2.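

In this assay, the 2H-indazol-6-yl on a nitrogen on an aromatic ring brings a 27-fold lower number from compound 2 to compound 3 (1.43 log units; beyond the scatter), which shows that this position can give a low number without any nitrophenyl, and that the high number of compound 2 belongs to the 3-nitrophenyl rather than to the shared core. The exchange against the better nitrophenyl is much smaller, with a 2.4-fold higher number from compound 1 to compound 3 (0.38 log units; beyond the scatter), so the 2H-indazol-6-yl recovers most of the ground but still leaves compound 1 with the lowest number of the three, beyond the scatter. Nothing shown here accounts for why either exchange moves the read-out as it does.

The compounds shown leave open whether a low number at this position depends on the hydrogen-bond donor that enters with the 2H-indazol-6-yl, or whether compound 1 and compound 3 reach their low numbers in unrelated ways. A plain phenyl, a 4-aminophenyl or a 4-carboxyphenyl on this nitrogen would help to separate these readings, as would an indazolyl joined through another ring carbon.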